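Two Chlorines in Place of One Fluorine

The source may hold more compounds than are shown below. What is called first, only, known or untested is meant among the compounds shown, and "the series" means these compounds.

Three compounds share a core and were tested in a functional assay on PC-3 cells (Homo sapiens) for inhibition, read by MTT assay, with a stated time of 72 h; on this read-out higher numbers stand for weaker inhibition and lower numbers for stronger inhibition. Compound 1 `O=C(CSc1nc(Nc2ccccc2)c2ccccc2n1)Nc1ccccc1F` gives 12400 nM, compound 2 `O=C(CSc1nc(Nc2ccccc2)c2ccccc2n1)Nc1ccc(F)cc1` gives 9560 nM, and compound 3 `C=CC(=O)Nc1cccc(NC(=O)CSc2nc(Nc3ccccc3F)c3ccccc3n2)c1` gives 9340 nM. Compound 3 sits alongside the other two: its gaps to compound 2 and to compound 1 both fall within the usual scatter. Compound 4 `C=CC(=O)Nc1cccc(NC(=O)CSc2nc(Nc3ccc(Cl)c(Cl)c3)c3ccccc3n2)c1` differs from compound 3 in one place: 3,4-dichlorophenyl in place of 2-fluorophenyl on a nitrogen on an aromatic ring. Within the data shown here, the only measured step, a 1.3-fold lower number from compound 1 to compound 2 (0.11 log units; within the scatter), altered a fluorophenyl at a different site, on an amide-type nitrogen, and stayed within the scatter, so it bears only loosely on this change. Among the measured compounds shown here, no measured step touches the group on the ring nitrogen. The step of a 1.2-fold lower number from compound 3 to compound 4 (0.07 log units; within the scatter) is therefore expected to stay within the scatter. The estimate for compound 4 is 8000 nM, in the range 3000 nM to 25000 nM.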

Compound 4, half-maximal inhibitory concentration: 27600 nM
Compound 4: middle estimate off by 3.5-fold (0.54 log units), on the low side, and the stated range ends below it.
By their numbers in this assay, from the lowest: compounds 3, 2 and 1 (each within the scatter of the next); then compound 4.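

The group on the nitrogen on an aromatic ring proves to matter in this assay: 3,4-dichlorophenyl in place of 2-fluorophenyl gives weaker inhibition (a 3.0-fold higher number from compound 3 to compound 4 (0.47 log units; beyond the scatter)). Among these compounds, this is the first step beyond the scatter, whereas the only earlier step (a 1.3-fold lower number from compound 1 to compound 2 (0.11 log units; within the scatter)) changed a fluorophenyl at another site and stayed within it. Nothing available here explains the change.

On these data alone, it remains open whether losing the fluorine or gaining the two chlorines drives this step. A phenyl with a single chlorine, a methoxy group or an amine at this nitrogen could help separate the two.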